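The compounds below may be only part of what the source reports. "The series", "measured", "known", "first", "only" and "open" are said of these compounds alone.

Compound 1 `CCN(CC)S(=O)(=O)c1ccc(S(=O)(=O)N2CCC[C@@H](C(=O)N[C@H]3CC[C@@H](OC)CC3)C2)cc1` — 590 nM
Compound 2 `CCN(CC)S(=O)(=O)c1ccc(S(=O)(=O)N2CCC[C@@H](C(=O)N3CCS(=O)(=O)CC3)C2)cc1` — 220 nM

Both values come from a functional assay on MIA PaCa-2 cells (Homo sapiens) for inhibition, read by MTT assay, with a stated time of 3 days; a lower number here means a stronger inhibitor, a higher number a weaker inhibitor. Compound 2 holds the lower of the two numbers, and the step of a 2.7-fold lower number from compound 1 to compound 2 (0.43 log units; beyond the scatter) lies beyond the scatter. Compound 3 `CCN(CC)S(=O)(=O)c1ccc(S(=O)(=O)N2CCC[C@@H](C(=O)N3CC[C@H](OC)C3)C2)cc1` differs from compound 2 by 3-methoxypyrrolidin-1-yl in place of 1,1-dioxothiomorpholin-4-yl on a carbonyl carbon. Going by the values given here, no measured step covers this exact swap. Among the compounds with values here, the one step known, a 2.7-fold lower number from compound 1 to compound 2 (0.43 log units; beyond the scatter), lowered the number when 1,1-dioxothiomorpholin-4-yl replaced (4-methoxycyclohexyl)amino, so bringing back a methoxy-bearing partner is expected to give up part of that gain. Compound 3 is therefore estimated at 350 nM, within 150 nM to 900 nM, a step of a 1.6-fold higher number from compound 2 to compound 3 (0.20 log units; within the scatter).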

Compound 3, half-maximal inhibitory concentration: 460 nM
Compound 3: the middle estimate sits 1.3-fold (0.12 log units) below what was measured; the measured number falls inside the stated range.
By their numbers in this assay, from the lowest: compound 2; then compounds 3 and 1 (each within the scatter of the next).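

At this carbonyl carbon, the advantage of 1,1-dioxothiomorpholin-4-yl is not shared by 3-methoxypyrrolidin-1-yl (a 2.1-fold higher number from compound 2 to compound 3 (0.32 log units; beyond the scatter)). Going by these compounds alone, the two methoxy-bearing partners, (4-methoxycyclohexyl)amino and 3-methoxypyrrolidin-1-yl, cannot be told apart (a 1.3-fold lower number from compound 1 to compound 3 (0.11 log units; within the scatter)), leaving 1,1-dioxothiomorpholin-4-yl as the only one of the three groups that stands apart. Nothing measured here gives a reason for this. Still open, on these data alone, is whether a morpholin-4-yl group at this carbonyl carbon would fall with compound 2 or with compound 3, and whether the opposite stereocentre in the 3-methoxypyrrolidin-1-yl group would change the number.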